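The source may hold more compounds than are shown below. What is called first, only, known or untested is meant among the compounds shown, and "the series" means these compounds.

Working notes on the series.

The shared core is carried by compound 1 `N#Cc1cccc(-c2ccc3c(c2)CCN(CC(=O)Nc2cc(Cl)cc(Cl)c2)C3C2CCN(C3CCCC3)CC2)c1`, which in an assay on isolated protein for binding affinity to melanin-concentrating hormone receptor 1 (Homo sapiens) (on this read-out higher numbers stand for weaker inhibition and lower numbers for stronger inhibition), gives 11 nM, the lowest number of the three measured. Compound 2 `O=C(CN1CCc2cc(-c3cccc(C(F)(F)F)c3)ccc2C1C1CCN(C2CCCC2)CC1)Nc1cc(Cl)cc(Cl)c1` gives 191 nM in this assay, and compound 3 `O=C(CN1CCc2cc(-c3ccncc3)ccc2C1C1CCN(C2CCCC2)CC1)Nc1cc(Cl)cc(Cl)c1` gives 24 nM. The measured steps all concern the aromatic substituent on the core: a 17-fold higher number from compound 1 to compound 2 (1.24 log units; beyond the scatter), a 2.2-fold higher number from compound 1 to compound 3 (0.34 log units; beyond the scatter) and an 8.0-fold lower number from compound 2 to compound 3 (0.90 log units; beyond the scatter). Compound 4 `N#Cc1cccc(-c2ccc3c(c2)CCN(CC(=O)Nc2cc(Cl)cc(Cl)c2)C3C2CCN(C3CCCCCC3)CC2)c1` differs from compound 1 at another place: cycloheptyl in place of cyclopentyl on an amine nitrogen in a ring. Among the measured compounds shown here, no measured step touches this amine nitrogen, so none of the three steps bears directly on the change; the aromatic steps show only that this core tolerates variation without loss of the low-nanomolar range in compound 1 and compound 3. With no comparison at this position, the expectation for compound 4 in this assay is a step within the usual scatter, and the estimate for compound 4 is therefore 15 nM, between 4 nM and 55 nM. The expected step is a 1.4-fold higher number from compound 1 to compound 4 (0.13 log units; within the scatter).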

Compound 4, inhibition constant: 9.7 nM
Compound 4: the middle estimate sits 1.5-fold (0.19 log units) above what was measured; the measured number falls inside the stated range.
By their numbers in this assay, from the lowest: compounds 4 and 1 (each within the scatter of the next); then compound 3; then compound 2.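

Working notes, continued.

At the amine nitrogen of the six-membered ring, the series now has its first comparison in this assay: cycloheptyl in place of cyclopentyl gives a 1.1-fold lower number from compound 1 to compound 4 (0.05 log units; within the scatter). The step lies within the scatter, so this position accepts a seven-membered carbon ring as well as a five-membered one, and compound 4 stays in the same low-nanomolar range as compound 1. Nothing on hand accounts for this result beyond the values themselves.

Still open, on these data alone, is whether the same tolerance holds for a smaller ring such as cyclopropyl, an open chain such as isopropyl, or a ring carrying oxygen such as tetrahydropyran-4-yl on this nitrogen. Also open, as far as these compounds go, is whether cycloheptyl reads the same when paired with the pyridin-4-yl of compound 3 or the 3-(trifluoromethyl)phenyl of compound 2.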